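The source may hold more compounds than are shown below. What is called first, only, known or untested is meant among the compounds shown, and "the series" means these compounds.

Measured so far in a functional assay on HEK293 cells for agonist activity at G-protein coupled receptor 39 (Mus musculus), read by inositol phosphate accumulation; on this read-out higher numbers stand for an effect only at larger amounts of compound and lower numbers for an effect already at smaller amounts:

- compound 1 `CNC(=O)c1ccc(CNc2cc(-c3ccccn3)nc(NC)n2)cc1`, 8 nM
- compound 2 `CNc1nc(NCc2ccc(NS(C)(=O)=O)cc2)cc(-c2ccccn2)n1`, 8 nM

Compound 2 stands level with compound 1 at the digits shown; the step of no change at the digits printed from compound 1 to compound 2 (within the scatter) lies within the scatter. Compound 3 `CNc1nc(NCc2ccc(N(C)C(C)=O)cc2)cc(-c2ccccn2)n1` has not been measured. The change from compound 2 is acetyl(methyl)amino in place of methanesulfonamido on an aromatic carbon. Going by the values given here, only one measured step bears on it: from compound 1 to compound 2 a group on the same aromatic carbon was exchanged, and the value did not move beyond the scatter (no change at the digits printed from compound 1 to compound 2 (within the scatter)). Compound 3 also keeps the whole remaining structure of compound 2. The expectation for compound 3 in this assay is therefore a small step or none beyond the scatter, most likely toward a somewhat higher number, expected as a 1.5-fold higher number from compound 2 to compound 3 (0.18 log units; within the scatter). For compound 3 the estimate in this assay is 12 nM, expected to fall between 4 nM and 40 nM.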

Compound 3, half-maximal effective concentration: 2610 nM
Compound 3: middle estimate off by 220-fold (2.34 log units), on the low side; the measured number lies above the stated range.
By their numbers in this assay, from the lowest: compounds 1 and 2 (each within the scatter of the next); then compound 3.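

In this assay, the aromatic carbon para to a large group proves far less tolerant than the earlier exchange there suggested, which gave no change at the digits printed from compound 1 to compound 2 (within the scatter). Acetyl(methyl)amino in place of methanesulfonamido gives a 330-fold higher number from compound 2 to compound 3 (2.51 log units; beyond the scatter), and acetyl(methyl)amino in place of methylcarbamoyl gives a 330-fold higher number from compound 1 to compound 3 (2.51 log units; beyond the scatter), so two different groups hold the low number while this one does not, although it has the same heavy-atom count as methanesulfonamido and differs from it in having 0 hydrogen-bond donors rather than 1. No measurement at hand accounts for this large step.

The compounds shown leave open whether the step follows the methyl on the nitrogen or the acetyl itself, and acetamido, the same group without that methyl, would separate the two. Going by these compounds, how an amine or a carboxylic acid on this carbon would read also remains open.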